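The source may hold more compounds than are shown below. What is called first, only, known or untested is meant among the compounds shown, and "the series" means these compounds.

The series shares one core, shown in compound 1 `NS(=O)(=O)c1ccc(Nc2nc(N/N=C/c3ccc(C(F)(F)F)cc3)nc(Nc3ccccc3)n2)cc1` and compound 2 `Cc1nn(-c2ccccc2)cc1/C=N/Nc1nc(Nc2ccccc2)nc(Nc2ccc(S(N)(=O)=O)cc2)n1`, and differs only in the aryl group on a carbon with a double bond to nitrogen. In a functional assay on K562 cells (Homo sapiens) for inhibition, read by sulforhodamine B assay, with a stated time of 48 h (a higher number here means a weaker inhibitor of growth, a lower number a stronger inhibitor of growth), compound 1 gives 3510 nM. In this assay compound 2 gives 2630 nM. For the measured compounds named here, the single step between them, a 1.3-fold lower number from compound 1 to compound 2 (0.13 log units; within the scatter), replaces 4-(trifluoromethyl)phenyl with 3-methyl-1-phenyl-1H-pyrazol-4-yl; compound 2 and compound 1 therefore sit within the scatter of one another, and neither can be called the stronger inhibitor on these two numbers.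

Compound 3 `NS(=O)(=O)c1ccc(Nc2nc(N/N=C/c3ccccn3)nc(Nc3ccccc3)n2)cc1` continues at the same place: pyridin-2-yl in place of 3-methyl-1-phenyl-1H-pyrazol-4-yl on a carbon with a double bond to nitrogen. Going by the values given here, only one measured step bears on this position, the step from compound 1 to compound 2, and it stayed within the scatter even though the entering group there was larger than the group it replaced. Among the compounds with values here, nothing among the measured compounds shows that this carbon is sensitive to the aryl group attached to it. For compound 3 the expected step in this assay is a 1.1-fold higher number from compound 2 to compound 3 (0.06 log units; within the scatter), that is, none beyond the scatter. Compound 3 is therefore estimated at 3000 nM, within a range of 1200 nM to 8000 nM.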

Compound 3, concentration for 50% growth inhibition: 400 nM
The estimate for compound 3 lay 7.5-fold (0.88 log units) above the measured number; measured number below the stated range.
By their numbers in this assay, from the lowest: compound 3; then compounds 2 and 1 (each within the scatter of the next).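

The carbon with a double bond to nitrogen proves sensitive to the aryl group it carries: in this assay, pyridin-2-yl gives a 6.6-fold lower number from compound 2 to compound 3 (0.82 log units; beyond the scatter) and an 8.8-fold lower number from compound 1 to compound 3 (0.94 log units; beyond the scatter), although the two groups it replaces had stayed within the scatter of each other. Size and ring content both change in the step from compound 2 to compound 3, with fewer heavy atoms entering than leaving, and a hetero atom in the ring does not by itself mark out the lower number, since 3-methyl-1-phenyl-1H-pyrazol-4-yl in compound 2 also has hetero atoms in a ring. Nothing available explains why pyridin-2-yl stands apart from the other two groups.

The three compounds leave open whether the lower number follows the ring nitrogen, where that nitrogen sits, or simply the smaller group. A plain phenyl, pyridin-3-yl or pyridin-4-yl on this carbon would begin to separate these readings, and a substituent such as methyl or an amine on the pyridin-2-yl ring would show how much change the group tolerates.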